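The source may hold more compounds than are shown below. What is called first, only, known or untested is meant among the compounds shown, and "the series" means these compounds.

Measured compounds in an assay for inhibition of Alpha amylase (Homo sapiens), with a stated time of 10 min; on this read-out lower numbers stand for stronger inhibition and higher numbers for weaker inhibition:
Compound 1 `COc1cccc(-c2nc3cc(F)ccc3[nH]2)c1Cl` gives 2620 nM.
Compound 2 `COc1ccc(Br)c(-c2nc3cc(F)ccc3[nH]2)c1O` gives 2170 nM.
Compound 3 `COc1cccc(-c2nc3cc(Cl)ccc3[nH]2)c1Cl` gives 2780 nM.

Compound 3 is compound 1 with one change, (chloro in place of fluoro on an aromatic carbon). This step gave a 1.1-fold higher number from compound 1 to compound 3 (0.03 log units; within the scatter), so the two values sit together within the usual scatter. Compound 2 carries a different core from compound 1; how the two cores differ is not broken down here, and the values of compound 1 and compound 2 also sit within the scatter of one another. Compound 4 `COc1ccc(Br)c(-c2nc3cc(Cl)ccc3[nH]2)c1O` has not yet been measured in this assay. It is compound 2 with chloro in place of fluoro on an aromatic carbon, the same change, at the same kind of place, as that from compound 1 to compound 3. Because a 1.1-fold higher number from compound 1 to compound 3 (0.03 log units; within the scatter) stayed within the scatter, compound 4 is expected to stay close to compound 2, with an estimated step of a 1.1-fold higher number from compound 2 to compound 4 (0.03 log units; within the scatter). Compound 4 is therefore estimated at 2300 nM in this assay, expected to fall between 1200 nM and 4500 nM.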

Compound 4, half-maximal inhibitory concentration: 2210 nM
Beside the measured number, compound 4's estimate is 1.0-fold (0.02 log units) above it; measured number inside the range.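

In this assay, chloro in place of fluoro on an aromatic carbon gave a 1.0-fold higher number from compound 2 to compound 4 (0.01 log units; within the scatter), a step that cannot be told apart from repeat measurement. Set beside the earlier step, it does not differ from it: the same change on two cores in this assay, a 1.1-fold higher number (0.03 log units; within the scatter) from compound 1 to compound 3 and a 1.0-fold higher number (0.01 log units; within the scatter) from compound 2 to compound 4, 1.0-fold (0.02 log units) apart, within the scatter of two such steps. This shows that, on these two cores, the change carried over as a step within the scatter, but it rests on two pairs only, and it does not show that the step would stay this small on a further core or in another assay.

The compounds shown carry only fluoro or chloro on that aromatic carbon, so it remains open whether a group such as an amine, a nitrile or a carboxylic acid there would keep the values in the same range. As far as these compounds go, it also remains open whether the two cores would respond alike to such a larger replacement, as two halogens cannot settle that question.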